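Trimethoxyphenyl replaces phenylethenyl on the saturated ring carbon

The source may hold more compounds than are shown below. What is called first, only, known or untested is meant among the compounds shown, and "the series" means these compounds.

The two measured compounds share one core and differ only in the group on a saturated ring carbon. Compound 1 `Cc1cc(O)c(C2=NN(c3ccc(S(N)(=O)=O)cc3)C(c3ccccc3Cl)C2)cc1Cl` carries a 2-chlorophenyl group there, and in a functional assay on COLO 205 cells (Homo sapiens) for antiproliferative activity, with a stated time of 48 h (a higher number here means that more compound is tolerated, a lower number that less compound is tolerated), compound 1 gives 6030 nM. Compound 2 `Cc1cc(O)c(C2=NN(c3ccc(S(N)(=O)=O)cc3)C(/C=C/c3ccccc3)C2)cc1Cl` carries a 2-phenylethenyl group instead, and in this assay compound 2 gives 47000 nM. Among the compounds with values here, the single measured step, a 7.8-fold higher number from compound 1 to compound 2 (0.89 log units; beyond the scatter), leaves compound 2 at the highest of the two numbers, with compound 1 as its nearest neighbour at the lower value.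

Compound 3 `COc1ccc(C2CC(c3cc(Cl)c(C)cc3O)=NN2c2ccc(S(N)(=O)=O)cc2)c(OC)c1OC` is not yet measured. It differs from compound 2 in one place: 2,3,4-trimethoxyphenyl in place of 2-phenylethenyl on a saturated ring carbon. Within the data shown here, the only step that bears on this position is a 7.8-fold higher number from compound 1 to compound 2 (0.89 log units; beyond the scatter), which shows that replacing an aromatic ring by the 2-phenylethenyl group raised the number beyond the scatter. Returning to an aromatic ring at the same carbon is therefore expected to bring the number back down, although no measured pair addresses the trimethoxy pattern itself, so the expectation is broad. Compound 3 is expected to give 10000 nM in this assay, within a range from 3000 nM to 35000 nM. The expected step is a 4.7-fold lower number from compound 2 to compound 3 (0.67 log units; beyond the scatter).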

Compound 3, concentration lethal to 50% of the cells: 5560 nM
The estimate for compound 3 lay 1.8-fold (0.25 log units) above the measured number; measured number inside the range.
By their numbers in this assay, from the lowest: compounds 3 and 1 (each within the scatter of the next); then compound 2.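

In this assay, the move away from 2-phenylethenyl gives an 8.5-fold lower number from compound 2 to compound 3 (0.93 log units; beyond the scatter), so this step on the saturated ring carbon is now seen from a second substituted phenyl group and not only from 2-chlorophenyl. The two phenyl groups themselves differ widely, with 2,3,4-trimethoxyphenyl bringing three oxygen atoms and more heavy atoms, yet the comparison between them gives a 1.1-fold lower number from compound 1 to compound 3 (0.04 log units; within the scatter), so among the three compounds shown, 2-phenylethenyl alone stands apart and the change from 2-chlorophenyl to 2,3,4-trimethoxyphenyl registers no difference in this read-out. Nothing measured here offers an explanation for either step.

The compounds shown leave open whether the double bond matters, which a 2-phenylethyl group at the same carbon would test, and whether a group without any aromatic ring, such as a cyclohexyl ring or a chain carrying an amine or a carboxylic acid, would fall with compound 2 or with compounds 1 and 3. Going by these compounds, they also cannot separate the three methoxy groups of compound 3 from one another, so the part each plays at this position remains unknown.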